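The source may hold more compounds than are shown below. What is called first, only, known or untested is meant among the compounds shown, and "the series" means these compounds.

Of the compounds shown here, three sharing one core have been measured in a functional assay on SGC-7901 cells (Homo sapiens) for antiproliferative activity, read by MTT assay, with a stated time of 72 h; a lower number here means a stronger inhibitor, a higher number a weaker inhibitor. Compound 1 `COc1ccc(-c2ccc3ncn(-c4cc(OC)c(OC)c(OC)c4)c3c2)cc1O` gives 44 nM in this assay. Compound 2 `COc1ccc(-c2ccc3ncn(-c4cc(OC)c(OC)c(OC)c4)c3c2)cc1F` gives 430 nM, and compound 3 `COc1cc(-n2cnc3ccc(-c4cccc(C)c4C)cc32)cc(OC)c1OC` gives 3040 nM. Compound 2 stands second highest of the three numbers: a 9.8-fold higher number from compound 1 to compound 2 (0.99 log units; beyond the scatter), while a 7.1-fold higher number from compound 2 to compound 3 (0.85 log units; beyond the scatter). Compound 4 `COc1cc(-n2cnc3ccc(-c4cccc([N+](=O)[O-])c4)cc32)cc(OC)c1OC` has not yet been measured; it differs from compound 2 in one place: 3-nitrophenyl in place of 3-fluoro-4-methoxyphenyl on an aromatic carbon. The closest guide is the exchange of the whole aryl group in a 7.1-fold higher number from compound 2 to compound 3 (0.85 log units; beyond the scatter), a modest weakening, and a 9.8-fold higher number from compound 1 to compound 2 (0.99 log units; beyond the scatter) shows that the substituents on that aryl group matter. The expected step is a 2.3-fold higher number from compound 2 to compound 4 (0.37 log units; beyond the scatter), a weakening of similar size. Compound 4 is therefore estimated at 1000 nM, with a range of 300 nM to 3500 nM.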

Compound 4, half-maximal inhibitory concentration: 380 nM
Compound 4: middle estimate off by 2.6-fold (0.42 log units), on the high side, within the range that was stated.
By their numbers in this assay, from the lowest: compound 1; then compounds 4 and 2 (each within the scatter of the next); then compound 3.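

In this assay, a phenyl group without methoxy can match one with it: 3-nitrophenyl and 3-fluoro-4-methoxyphenyl show no readable difference, with a 1.1-fold lower number from compound 2 to compound 4 (0.05 log units; within the scatter). Replacing the aryl group therefore does not always cost as much as 2,3-dimethylphenyl did, with an 8.0-fold lower number from compound 3 to compound 4 (0.90 log units; beyond the scatter), while 3-hydroxy-4-methoxyphenyl remains ahead, with an 8.6-fold higher number from compound 1 to compound 4 (0.94 log units; beyond the scatter). Nothing available here accounts for these differences. Still open, from the compounds shown here alone, is how an amine or a carboxylic acid in place of the nitro group of compound 4 would read in this assay.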